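A few compounds are considered here, and "the series" means these few. Any claim that something is new, unique, unknown or untested is made for them only; others in the source may bear on it.

Values measured so far in a functional assay on A549 cells (Homo sapiens) for inhibition, read by MTT assay, with a stated time of 72 h; a higher number here means a weaker inhibitor, a lower number a stronger inhibitor:
- compound 1 `O=C1/C(=C\c2ccccc2)c2c(ncn2COCc2ccccc2)CCN1Cc1ccccc1`: 9900 nM
- compound 2 `Cc1ccc(CN2CCc3ncn(COCc4ccccc4)c3/C(=C/c3ccccc3)C2=O)cc1`: 11400 nM
- compound 3 `O=C1/C(=C\c2ccccc2)c2c(ncn2COCc2ccccc2)CCN1Cc1ccc(F)cc1`: 19600 nM

The three compounds share one core and differ only in the benzyl group. Compound 3 sits within the scatter of both other compounds, so this small set shows no order in this assay. The next compound is compound 4 `Cc1cc(C)cc(CN2CCc3ncn(COCc4ccccc4)c3/C(=C/c3ccccc3)C2=O)c1`. The change is 3,5-dimethylphenyl in place of 4-fluorophenyl on a saturated chain carbon bound to an amide-type nitrogen in a ring, which amounts to 3,5-dimethylphenyl in place of 4-fluorophenyl on a saturated chain carbon bound to an amide-type nitrogen in a ring.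

Among the compounds with values here, three measured steps bear on this change: a 1.2-fold higher number from compound 1 to compound 2 (0.06 log units; within the scatter), a 2.0-fold higher number from compound 1 to compound 3 (0.30 log units; within the scatter) and a 1.7-fold higher number from compound 2 to compound 3 (0.24 log units; within the scatter). All three are changes on the same aromatic ring, and none goes beyond the scatter. Within the data shown here, no measured compound carries 3,5-dimethylphenyl, so the second methyl group is untested and the estimate has to stay wide. No step beyond the scatter is expected in this assay, and no firm direction can be claimed. The expected change is a 1.5-fold lower number from compound 3 to compound 4 (0.18 log units; within the scatter). For compound 4 the estimated value is 13000 nM, with an expected range of 6000 nM to 26000 nM.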

Compound 4, half-maximal inhibitory concentration: 22500 nM
Estimate against measurement, compound 4: 1.7-fold (0.24 log units) below, and the stated range covers the measured number.
By their numbers in this assay, from the lowest: compounds 1, 2, 3 and 4 (each within the scatter of the next, the first and the last beyond it).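

In this assay, within the data shown here, 3,5-dimethylphenyl in place of phenyl on a saturated chain carbon bound to an amide-type nitrogen in a ring gives the first step beyond the scatter at this position (a 2.3-fold higher number from compound 1 to compound 4 (0.36 log units; beyond the scatter)), though a modest one. The other two new steps stay within the scatter (a 1.1-fold higher number from compound 3 to compound 4 (0.06 log units; within the scatter); a 2.0-fold higher number from compound 2 to compound 4 (0.30 log units; within the scatter)), so 3,5-dimethylbenzyl is not separated from 4-fluorobenzyl or 4-methylbenzyl, and only the two ends of this short series stand apart, with compounds 2 and 3 not distinguished from either neighbour. Among these compounds, no supporting measurement accounts for the one step that clears the scatter.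

Going by these compounds, the groups on this benzyl ring are limited to hydrogen, fluoro and methyl, so it remains open whether an amine or a carboxylic acid on the ring, or a longer chain in place of the benzyl group, would move the number further than the modest step seen here. The single-methyl and double-methyl compounds also differ in more than one respect, which leaves the separate contribution of each methyl group unresolved.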